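Aryl amide variation on a shared flavonol core

The source may report more compounds than this note shows. Statements on the series, on what has been measured and on what is new or still open speak of the compounds shown alone.

Measured so far:
- compound 1 `COc1ccc(C(=O)Nc2cccc(-c3oc4cc(-c5ccc(F)cc5)ccc4c(=O)c3O)c2)cc1`: 5490 nM
- compound 2 `O=C(Nc1cccc(-c2oc3cc(-c4ccc(F)cc4)ccc3c(=O)c2O)c1)c1ccc(F)cc1F`: 6980 nM
- compound 3 `O=C(Nc1cccc(-c2oc3cc(-c4ccc(F)cc4)ccc3c(=O)c2O)c1)c1ccc(Br)cc1`: 8630 nM

In a functional assay on HCC1937 cells (Homo sapiens) for antiproliferative activity, read by CCK-8 assay, with a stated time of 72 h (a higher number here means a weaker inhibitor, a lower number a stronger inhibitor), the three numbers lie close together. Compound 3 is reached by a 1.6-fold higher number from compound 1 to compound 3 (0.20 log units; within the scatter) and by a 1.2-fold higher number from compound 2 to compound 3 (0.09 log units; within the scatter), so no ordering among the three can be claimed. Compound 4 `O=C(Nc1cccc(-c2oc3cc(-c4ccc(F)cc4)ccc3c(=O)c2O)c1)c1cc(F)cc(F)c1` differs from compound 3 in one place: 3,5-difluorophenyl in place of 4-bromophenyl on a carbonyl carbon. Among the compounds with values here, the steps that bear on this are the aryl exchanges a 1.3-fold higher number from compound 1 to compound 2 (0.10 log units; within the scatter) and a 1.2-fold higher number from compound 2 to compound 3 (0.09 log units; within the scatter), both within the scatter. Compound 4 is therefore expected to stay near compound 3, with a step of a 1.2-fold lower number from compound 3 to compound 4 (0.09 log units; within the scatter) of no real size. For compound 4 the estimate is 7000 nM, in the range 3500 nM to 14000 nM.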

Compound 4, half-maximal inhibitory concentration: 2070 nM
The estimate for compound 4 lay 3.4-fold (0.53 log units) above the measured number, outside the stated range (below it).
By their numbers in this assay, from the lowest: compound 4; then compounds 1, 2 and 3 (each within the scatter of the next).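

In this assay, the aryl group on the amide carbonyl carbon proves able to move the number: 3,5-difluorophenyl gives a 4.2-fold lower number from compound 3 to compound 4 (0.62 log units; beyond the scatter), a 3.4-fold lower number from compound 2 to compound 4 (0.53 log units; beyond the scatter) and a 2.7-fold lower number from compound 1 to compound 4 (0.42 log units; beyond the scatter), all beyond the scatter, whereas the earlier exchanges stayed within it. The second of these steps exchanges 2,4-difluorophenyl for 3,5-difluorophenyl, so the fluorine pattern matters here, not merely the presence of fluorine. Nothing available accounts for this difference. Going by these compounds, whether other groups on that carbonyl carbon, such as a dichlorophenyl, an aminophenyl or a pyridyl ring, would match 3,5-difluorophenyl remains open.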